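Adding a nitro group to compound 1

A few compounds are considered here, and "the series" means these few. Any claim that something is new, unique, unknown or untested is made for them only; others in the source may bear on it.

- compound 1 `O=C1CCCCC/C1=C\c1ccccc1`: 110000 nM
- compound 2 `O=C1CCCCC/C1=C\c1ccc(Cl)cc1`: 43500 nM
- compound 3 `O=C1CCCCC/C1=C\c1ccc(Br)cc1`: 42800 nM

Among these three in a functional assay on CCRF-CEM cells (Homo sapiens) for inhibition (a lower number here means a stronger inhibitor, a higher number a weaker inhibitor), compound 1 stands highest at 110000 nM and is the weakest inhibitor. Within the data shown here, compound 4 `O=C1CCCCC/C1=C\c1cccc([N+](=O)[O-])c1` keeps the core of compound 1 and has nitro in place of hydrogen on an aromatic carbon as its only change. The closest guides are two halogen swaps, each modest: a 2.5-fold lower number from compound 1 to compound 2 (0.40 log units; beyond the scatter) and a 2.6-fold lower number from compound 1 to compound 3 (0.41 log units; beyond the scatter). Between the halogens, a 1.0-fold lower number from compound 2 to compound 3 (0.01 log units; within the scatter) stays within the scatter. Neither halogen is a nitro group, so the guide is loose. A modest step toward stronger inhibition is expected, estimated as a 2.0-fold lower number from compound 1 to compound 4 (0.30 log units; within the scatter) in this assay overall. Compound 4 is estimated at 55000 nM with an expected range from 22000 nM to 120000 nM as the likely span.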

Compound 4, half-maximal inhibitory concentration: 30100 nM
Estimate against measurement, compound 4: 1.8-fold (0.26 log units) above; the measured number falls inside the stated range.
By their numbers in this assay, from the lowest: compounds 4, 3 and 2 (each within the scatter of the next); then compound 1.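

Measured in this assay the change to nitro gives a 3.7-fold lower number from compound 1 to compound 4 (0.56 log units; beyond the scatter) and so shows that a carbon of the ring meta to a group of 9 heavy atoms accepts a group larger than one halogen atom, with inhibition becoming stronger, not weaker. The earlier steps shown here covered only chloro and bromo in place of hydrogen. No measurement here explains this gain. As far as these compounds go, whether an amine or a methoxy group on the same carbon would move the number as far stays open, as does the step nitro would give elsewhere on the ring.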